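A few compounds are considered here, and "the series" means these few. Any claim that something is new, unique, unknown or untested is made for them only; others in the source may bear on it.

In a functional assay on MCF7 cells (Homo sapiens) for cytotoxicity, read by MTT assay, with a stated time of 72 h (a lower number here means a stronger inhibitor, a higher number a weaker inhibitor), compound 1 (`COC(=O)c1sc2cc(OC)ccc2c1Nc1cc(OC)c(OC)c(OC)c1`) gives 0.7 nM and compound 2 (`CCOC(=O)c1sc2cc(C)ccc2c1Nc1cc(OC)c(OC)c(OC)c1`) gives 9 nM as the higher of the two numbers. That gap lies beyond the usual scatter, but the two compounds differ in more than one place, so no single change can be credited with it. Compound 3 (`CCOC(=O)c1sc2cc(OC)ccc2c1Nc1cc(OC)c(OC)c(OC)c1`) differs from compound 2 in one place, with methoxy in place of methyl on an aromatic carbon is the whole of the change. Among the measured compounds shown here, no measured pair isolates this swap. For the measured compounds named here, the only guide is compound 1, which also carries a methoxy and gives 0.7 nM as its number, and only part of its gap to compound 2 can be expected to belong to this swap. A moderate step toward a lower number is therefore expected in this assay, probably beyond the scatter but short of the full gap. The expected size is a 3.6-fold lower number from compound 2 to compound 3 (0.56 log units; beyond the scatter) as an estimate. Compound 3 is estimated at 2.5 nM with an expected range from 0.7 nM to 9 nM in this measurement.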

Compound 3, half-maximal inhibitory concentration: 5.6 nM
The estimate for compound 3 lay 2.2-fold (0.35 log units) below the measured number; measured number inside the range.
By their numbers in this assay, from the lowest: compound 1; then compounds 3 and 2 (each within the scatter of the next).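

In this assay methoxy in place of methyl on an aromatic carbon gives a 1.6-fold lower number from compound 2 to compound 3 (0.21 log units; within the scatter), so this change, on the ring position that is meta to one fused ring and para to the other, separates the two groups by no more than repeat measurements would. The one step that clears the scatter lies at the other end of the molecule, where methyl in place of hydrogen on a saturated chain carbon bound to an oxygen next to a carbonyl group gives an 8.0-fold higher number from compound 1 to compound 3 (0.90 log units; beyond the scatter), so among these compounds the chain on that oxygen is the only place where a single change is shown to move the number. Nothing on hand explains either step.

The compounds shown leave open whether an amine or a chlorine on the same aromatic carbon would stay level with methyl and methoxy, and whether that level holds when the shorter chain is on the oxygen. From the compounds shown here alone, it also remains open how the number would respond to a longer chain on that oxygen, or to a carboxylic acid in place of the whole chain-bearing group.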